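Sulfonyl-chain amine variation in the acylurea benzothiazole series

A few compounds are considered here, and "the series" means these few. Any claim that something is new, unique, unknown or untested is made for them only; others in the source may bear on it.

Of the compounds shown here, two have numbers so far. Compound 1 `CN1CCC(S(=O)(=O)c2ccc3nc(NC(=O)NC(=O)c4cc5c(cc4Cl)CCN5C)sc3c2)CC1` carries a piperidinyl sulfonyl group on the shared core, and compound 2 `COCCNCCCS(=O)(=O)c1ccc2nc(NC(=O)NC(=O)c3ccccc3Cl)sc2c1` carries a sulfonyl chain ending in a (2-methoxyethyl)amino group. In an assay on HEK293 cells for displacement of a labelled ligand from growth hormone secretagogue receptor type 1 (Homo sapiens), with a stated time of 60 min (a higher number here means a weaker inhibitor, a lower number a stronger inhibitor), compound 1 gives 7.2 nM, and compound 2 gives 8.6 nM, the two values lying within the scatter of each other. Compound 3 `CN(C)CCCS(=O)(=O)c1ccc2nc(NC(=O)NC(=O)c3ccccc3Cl)sc2c1` has not been measured; it differs from compound 2 in one place: dimethylamino in place of (2-methoxyethyl)amino on a saturated chain carbon, three bonds along the chain from a sulfonyl sulfur. Within the data shown here, no measured pair isolates this kind of change, so nothing in the data fixes its size or direction. With compound 1 and compound 2 both in the same narrow band despite quite different sulfonyl substituents, the expected step from compound 2 to compound 3 in this assay is none beyond the scatter, a 1.0-fold higher number from compound 2 to compound 3 (0.02 log units; within the scatter). Compound 3 is therefore expected to give about 9 nM, in a range from 3 nM to 27 nM.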

Compound 3, half-maximal inhibitory concentration in the growth hormone secretagogue receptor type 1 assay: 8.7 nM
Beside the measured number, compound 3's estimate is 1.0-fold (0.01 log units) above it, within the range that was stated.
By their numbers in the growth hormone secretagogue receptor type 1 assay, from the lowest: compounds 1, 2 and 3 (each within the scatter of the next).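

Among these compounds, this pair is the first to isolate the amine at the end of the sulfonyl chain: in the growth hormone secretagogue receptor type 1 assay, dimethylamino in place of (2-methoxyethyl)amino gives a 1.0-fold higher number from compound 2 to compound 3 (0.01 log units; within the scatter). Within this pair, then, the assay does not separate the two amines, even though the hydrogen-bond donor of (2-methoxyethyl)amino is absent from dimethylamino. The same change does separate them in a physicochemical assay for lipophilicity (a higher number here means a more lipophilic compound, a lower number a more polar compound), where compound 2 gives 1.3 and compound 3 gives 1.7, so at this place on the chain lipophilicity shifts with no step beyond the scatter in the growth hormone secretagogue receptor type 1 assay: the measured distribution coefficient of compound 2, 1.3, and of compound 3, 1.7, a number 0.40 log units higher (beyond the scatter)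

Still open, going by these compounds, is how a primary amine, a morpholine or a carboxylic acid at the end of the chain, or a longer chain, would read in the growth hormone secretagogue receptor type 1 assay. One pair also cannot show whether the two read-outs stay apart for other amines at this place.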